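Two Amine Swaps on a Shared Urea Scaffold

The source may report more compounds than this note shows. Statements on the series, on what has been measured and on what is new or still open speak of the compounds shown alone.

Compound 1 `CCN(CC)Cc1ccc(NC(=O)N/N=C(\C)c2ccccn2)cc1` and compound 3 `C/C(=N\NC(=O)Nc1ccc(CN2CCC(C)CC2)cc1)c1ccccn1` have the same core and differ in one spot only: 4-methylpiperidin-1-yl in place of diethylamino on a saturated chain carbon bound to an aromatic carbon. The same change, at the same place, turns compound 2 `CCN(CC)Cc1ccc(NC(=O)NN=C(c2ccccn2)c2ccccn2)cc1` into the yet unmeasured compound 4 `CC1CCN(Cc2ccc(NC(=O)NN=C(c3ccccn3)c3ccccn3)cc2)CC1`: 4-methylpiperidin-1-yl in place of diethylamino on a saturated chain carbon bound to an aromatic carbon. Compound 2 and compound 1 carry different cores; the difference between the two cores is not broken down here.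

All three measured compounds were tested in a functional assay on U-937 cells (Homo sapiens) for antiproliferative activity, read by CCK-8 assay, with a stated time of 24 h; a higher number here means a weaker inhibitor, a lower number a stronger inhibitor. In this assay compound 1 is reported only as a limit of > 40000 nM, not as a number. Compound 3 likewise stops at the limit of > 40000 nM. For compound 2 the result is again a limit, > 40000 nM. The step that the two limits leave unreadable from compound 1 to compound 3, and this follows from the shared limit at which all three sit, (the limit of > 40000 nM in this assay, at which 3 of the 3 values shown sit).

For compound 4 the change from compound 2 is expected to yield a step that the limit leaves unreadable from compound 2 to compound 4, resting on the observation that compound 1 and compound 3, which carry this same change, both stay at the limit of > 40000 nM in this assay, at which 3 of the 3 values shown sit. Compound 4 is therefore expected to come out near 60000 nM, most likely reported once more as a limit rather than a number. The estimated range for compound 4 runs from 30000 nM to 120000 nM.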

Compound 4, half-maximal inhibitory concentration: > 40000 nM
Compound 4: only a limit was reported (the forecaster's own chance of this, stated with the estimate: 85%); the middle value is on the limit's open side.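

In this assay compound 4 gives > 40000 nM as a limit and not a number. Compound 2 also stops at a limit, so no step can be read from compound 2 to compound 4: (the limit of > 40000 nM in this assay, at which 4 of the 4 values shown sit). The compounds shown leave open how strongly any of them acts on these cells, and whether 4-methylpiperidin-1-yl and diethylamino differ in effect at all.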